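Swapping the aryl amide group of a dopamine receptor agonist

The compounds below may be only part of what the source reports. "The series", "measured", "known", "first", "only" and "open" are said of these compounds alone.

Compound 1, `Cc1cc(NC(=O)CN2CCC(c3cccc[n+]3[O-])CC2)ccc1F`: 75%
Compound 2, `O=C(CN1CCC(c2cccc[n+]2[O-])CC1)Nc1cccc(Cl)c1Cl`: 66%
Compound 3, `O=C(CN1CCC(c2cccc[n+]2[O-])CC1)Nc1ccc(F)cc1`: 71%

These three compounds share one core and differ only in the aryl group on the amide-type nitrogen. They were tested in a functional assay on HEK293 cells for agonist activity at D(4) dopamine receptor (Homo sapiens), read by FLIPR (on this read-out lower numbers stand for smaller maximal responses and higher numbers for larger maximal responses), and all three readings sit close together: the step of a number 4 percentage points lower from compound 1 to compound 3 (within the scatter) and the step of a number 5 percentage points higher from compound 2 to compound 3 (within the scatter) are both within the scatter, so compound 3 cannot be set apart from either neighbour. Compound 4, `Cc1cccc(C)c1NC(=O)CN1CCC(c2cccc[n+]2[O-])CC1`, has not been measured yet. It differs from compound 3 in one place: 2,6-dimethylphenyl in place of 4-fluorophenyl on an amide-type nitrogen. Among the compounds with values here, two measured steps bear on such a swap of the aryl group on the amide-type nitrogen: a number 9 percentage points lower from compound 1 to compound 2 (within the scatter) and a number 5 percentage points higher from compound 2 to compound 3 (within the scatter), both within the scatter. A step of that kind is therefore expected for compound 4 as well, namely a number 3 percentage points lower from compound 3 to compound 4 (within the scatter), with no change beyond the scatter. The expected value for compound 4 in this assay is 68%, with a range from 50% to 82%.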

Compound 4, largest response reached (reported as efficacy), in percent of the reference or control that the assay uses: 68%
Compound 4: the middle estimate sits on the measured number at the digits printed; the range from low to high includes it.
By their numbers in this assay, from the lowest: compounds 2, 4, 3 and 1 (each within the scatter of the next).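

At this amide-type nitrogen, 2,6-dimethylphenyl now joins the other aryl groups in this assay: the swap from 4-fluorophenyl gives a number 3 percentage points lower from compound 3 to compound 4 (within the scatter), the swap from 2,3-dichlorophenyl gives a number 2 percentage points higher from compound 2 to compound 4 (within the scatter), and the swap from 4-fluoro-3-methylphenyl gives a number 7 percentage points lower from compound 1 to compound 4 (within the scatter). An aryl group that carries two methyl groups and no halogen therefore cannot be told apart from the three halogen-bearing ones, so all four compounds form a single group on this read-out. Nothing measured here explains why these four groups give such similar responses.

On these data alone, whether a group of a different kind at this nitrogen, such as an amine, a carboxylic acid or a longer alkyl chain in place of the aryl ring, would move the response beyond the scatter remains open.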